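This account rests on a few compounds, and the source may have more. Where it says the series, first, only, none or still open, it means among the compounds named here.

Working notes on the series, read in an ADME assay on HEK293 cells (Homo sapiens) for cytotoxicity, read by ATP content, with a stated time of 6 h; a lower number here means that less compound is tolerated, a higher number that more compound is tolerated. Compound 1 (`COCCCNc1nc(N)nc2ccn(Cc3ccccn3)c12`) gives > 24000 nM as a limit of the assay, not a number. Compound 2 (`CCOCCNc1nc(N)nc2ccn(Cc3ccccn3)c12`) gives > 24000 nM as a limit too, so it has no readable number to stand on. The whole record so far is the limit of > 24000 nM in this assay, at which 2 of the 2 values shown sit, and nothing finer. The change to compound 3 (`CCC(O)CNc1nc(N)nc2ccn(Cc3ccccn3)c12`) is 1-hydroxypropyl in place of ethoxymethyl on a saturated chain carbon bound to a nitrogen on an aromatic ring and uses the same atoms, joined differently: the side chain reads 2-hydroxybutyl in place of 2-ethoxyethyl. Going by the values given here, no measured compound carries the 1-hydroxypropyl group. Among the compounds with values here, the only measured step is a step that the two limits leave unreadable from compound 1 to compound 2 and it supplies no size to carry over. On that thin basis, no step beyond the usual scatter is expected in this assay and no direction is assigned. The estimated move is a step that the limit leaves unreadable from compound 2 to compound 3 in this reading. For compound 3 the expected half-maximal cytotoxic concentration is 30000 nM with an estimated range from 15000 nM to 60000 nM and a report as a limit is the likelier outcome.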

Compound 3, half-maximal cytotoxic concentration: > 24000 nM
Compound 3: no number, only a limit (the forecaster's own chance of this, stated with the estimate: 80%); the middle value does not contradict the limit.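

No new step can be read among compound 1, compound 2 and compound 3 in this assay, and each result is a limit of the assay rather than a number: the limit of > 24000 nM in this assay, at which 3 of the 3 values shown sit.
The compounds shown leave open where the half-maximal cytotoxic concentration of each one lies, and whether 1-hydroxypropyl in place of ethoxymethyl shifts it at all.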